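The compounds below may be only part of what the source reports. "The series", "measured", "known", "first", "only" and "open" are said of these compounds alone.

Among the three compounds measured in an assay on membranes from liver for displacement of a labelled ligand from Sigma intracellular receptor 2 (Rattus norvegicus), read by scintillation counting, with a stated time of 120 min, in the presence of a further agent that is not named here (on this read-out lower numbers stand for stronger inhibition and higher numbers for weaker inhibition), compound 3 `OCc1cc2c(s1)CCC(NCCCc1ccccc1)CC2` stands alone with the highest number: compound 3 gives 30 nM, while compound 1 `c1ccc(CCCNC2CCc3ccsc3CC2)cc1` gives 5.1 nM and compound 2 `c1ccc(CCCCNC2CCc3ccsc3CC2)cc1` gives 5.7 nM. The gap that sets compound 3 apart is the step of a 5.9-fold higher number from compound 1 to compound 3 (0.77 log units; beyond the scatter), which came with hydroxymethyl in place of hydrogen on an aromatic carbon. The other comparison in this small set, a 1.1-fold higher number from compound 1 to compound 2 (0.05 log units; within the scatter), came with benzyl in place of phenyl on a saturated chain carbon, three bonds along the chain from an amine nitrogen, and it left this assay essentially unchanged.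

Compound 4 `OCc1cc2c(s1)CCC(NCCCCc1ccccc1)CC2` differs from compound 3 in exactly that second way: benzyl in place of phenyl on a saturated chain carbon, three bonds along the chain from an amine nitrogen. Among the measured compounds shown here, the only measured step bearing on this change is a 1.1-fold higher number from compound 1 to compound 2 (0.05 log units; within the scatter), and it did not rise above the scatter. For the measured compounds named here, no other pair in the set speaks to it. On that basis, the same change made on compound 3 is expected to produce no step beyond the scatter in this assay. The estimated step is a 1.1-fold higher number from compound 3 to compound 4 (0.03 log units; within the scatter), essentially flat. Compound 4 is therefore expected to give about 32 nM, with a likely range from 15 nM to 65 nM.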

Compound 4, inhibition constant: 73 nM
Compound 4: middle estimate off by 2.3-fold (0.36 log units), on the low side, and the stated range ends below it.
By their numbers in this assay, from the lowest: compounds 1 and 2 (each within the scatter of the next); then compound 3; then compound 4.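

On the core carrying hydroxymethyl, benzyl in place of phenyl on a saturated chain carbon, three bonds along the chain from an amine nitrogen, is no longer silent in this assay: it gives a 2.4-fold higher number from compound 3 to compound 4 (0.39 log units; beyond the scatter), so the longer group does not come free on every core. Even so, this step cannot be firmly set apart from the flat step seen on the core of compound 1, since the gap between the two lies within the scatter: the same change on two cores in this assay, a 1.1-fold higher number (0.05 log units; within the scatter) from compound 1 to compound 2 and a 2.4-fold higher number (0.39 log units; beyond the scatter) from compound 3 to compound 4, 2.2-fold (0.34 log units) apart, within the scatter of two such steps. The new compound also gives a second reading of hydroxymethyl in place of hydrogen on an aromatic carbon, a 13-fold higher number from compound 2 to compound 4 (1.11 log units; beyond the scatter), which points the same way as the first, towards a higher number, and its size agrees with that first reading within the scatter: the same change on two cores in this assay, a 5.9-fold higher number (0.77 log units; beyond the scatter) from compound 1 to compound 3 and a 13-fold higher number (1.11 log units; beyond the scatter) from compound 2 to compound 4, 2.2-fold (0.34 log units) apart, within the scatter of two such steps.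

With only two pairs for each change, the compounds shown cannot tell whether the two changes truly add up or whether the larger step with benzyl depends on the hydroxymethyl group. Going by these compounds, it also stays open how a carboxylic acid or an aminomethyl group on that aromatic carbon, or a still longer chain in place of benzyl, would read in this assay.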